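Cyclohexyl ester in place of hexyl ester

The source may report more compounds than this note shows. Statements on the series, on what has been measured and on what is new or still open speak of the compounds shown alone.

In an assay on Jurkat cells for inhibition of cyclic AMP-dependent transcription factor ATF-1 (Homo sapiens) (a lower number here means a stronger inhibitor, a higher number a weaker inhibitor), compound 1 `O=C(Nc1cc(C(F)(F)F)cc(C(F)(F)F)c1)c1cnc(Cl)nc1C(F)(F)F` gives 50 nM, compound 2 `NC(=O)c1cc(NC(=O)c2cnc(Cl)nc2C(F)(F)F)cc(C(F)(F)F)c1` gives 3000 nM, and compound 3 `CCCCCCOC(=O)c1cc(NC(=O)c2cnc(Cl)nc2C(F)(F)F)cc(C(F)(F)F)c1` gives 660 nM. Compound 3 thus stands second highest of the three numbers: a 13-fold higher number from compound 1 to compound 3 (1.12 log units; beyond the scatter), while a 4.5-fold lower number from compound 2 to compound 3 (0.66 log units; beyond the scatter). Compound 4 `O=C(OC1CCCCC1)c1cc(NC(=O)c2cnc(Cl)nc2C(F)(F)F)cc(C(F)(F)F)c1` differs from compound 3 by cyclohexyl in place of hexyl on an oxygen next to a carbonyl group. For the measured compounds named here, no measured step swaps one hydrocarbon group on that oxygen for another. The nearest comparison is the amide-to-ester change, a 4.5-fold lower number from compound 2 to compound 3 (0.66 log units; beyond the scatter), which was modest, and a 60-fold higher number from compound 1 to compound 2 (1.78 log units; beyond the scatter) concerns a change elsewhere on the shared core. With the ester kept intact, a step in this assay of modest size at most is expected, without a clear direction. For compound 4 an estimate of 600 nM is given, with a range from 200 nM to 2000 nM. This means that a 1.1-fold lower number from compound 3 to compound 4 (0.04 log units; within the scatter) is expected.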

Compound 4, half-maximal inhibitory concentration: 1200 nM
Beside the measured number, compound 4's estimate is 2.0-fold (0.30 log units) below it; the measured number falls inside the stated range.
By their numbers in this assay, from the lowest: compound 1; then compounds 3 and 4 (each within the scatter of the next); then compound 2.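

In this assay, cyclohexyl in place of hexyl on an oxygen next to a carbonyl group gives a 1.8-fold higher number from compound 3 to compound 4 (0.26 log units; within the scatter), so a ring of carbon and an open chain of the same six carbons are not told apart here. The cyclohexyl ester still stands clear of the amide, with a 2.5-fold lower number from compound 2 to compound 4 (0.40 log units; beyond the scatter), and clear of the trifluoromethyl compound, with a 24-fold higher number from compound 1 to compound 4 (1.38 log units; beyond the scatter). No evidence is available that bears on these results. From the compounds shown here alone, whether a methyl ester, a benzyl ester or a carboxylic acid in this place would come closer to compound 1 remains open.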